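Phenyl for Trifluoromethyl on Two Related Cores

This account rests on a few compounds, and the source may have more. Where it says the series, first, only, none or still open, it means among the compounds named here.

Compound 1 `CN(C)CCC(OC(=O)Nc1ccc(C(F)(F)F)cc1)c1ccc(Cl)cc1` and compound 2 `CN(C)CCC(OC(=O)Nc1ccc(-c2ccccc2)cc1)c1ccc(Cl)cc1` share one core, while compound 3 `CN(C)CCC(NC(=O)Nc1ccc(C(F)(F)F)cc1)c1ccc(Cl)cc1` and compound 4 `CN(C)CCC(NC(=O)Nc1ccc(-c2ccccc2)cc1)c1ccc(Cl)cc1` share another; the difference between the two cores is not broken down here. In an assay on NIH3T3 cells with Urotensin-2 receptor (Homo sapiens) as the target (a lower number here means a smaller maximal response, a higher number a larger maximal response), compound 1 gives 94% and compound 2 gives 58%. The change from compound 1 to compound 2 is phenyl in place of trifluoromethyl on an aromatic carbon and it produced a number 36 percentage points lower from compound 1 to compound 2 (beyond the scatter). In this assay compound 3 gives 105%, the highest of the three measured numbers. Compound 4 differs from compound 3 by phenyl in place of trifluoromethyl on an aromatic carbon, the same change made on the other core. The expectation for compound 4 rests on the step of a number 36 percentage points lower from compound 1 to compound 2 (beyond the scatter) applied to the value of compound 3, 105%. Compound 4 is therefore expected to reach about 69%, an estimated step of a number 36 percentage points lower from compound 3 to compound 4 (beyond the scatter), most likely between 50% and 90%.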

Compound 4, largest response reached (reported as efficacy), in percent of the reference or control that the assay uses: 91%
For compound 4 the middle estimate is 22 percentage points below the measured one, outside the stated range (above it).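

In this assay, phenyl in place of trifluoromethyl on an aromatic carbon lowers the maximal response on the second core as well, giving a number 14 percentage points lower from compound 3 to compound 4 (beyond the scatter). The direction of the change carries over from one core to the other, but its size does not: the same change on two cores in this assay, a number 36 percentage points lower (beyond the scatter) from compound 1 to compound 2 and a number 14 percentage points lower (beyond the scatter) from compound 3 to compound 4, 22 percentage points apart, beyond the scatter of two such steps. Two pairs of compounds cannot show why the size differs, nor whether the direction would hold on any further core.

The compounds shown leave open how other groups in the same place, such as a methyl, a nitrile or a carboxylic acid, would behave on these two cores. From the compounds shown here alone, whether a different amine at the end of the chain would alter the gap between the two steps also remains open.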